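The source may hold more compounds than are shown below. What is called first, only, known or untested is meant among the compounds shown, and "the series" means these compounds.

Working notes on the series. Three measured ureas share one core and differ only in the group on the amide-type nitrogen. Compound 1 `CCCCNC(=O)N1CC1C#N` carries a butyl chain; compound 2 `N#CC1CN1C(=O)Nc1ccc([N+](=O)[O-])cc1` and compound 3 `N#CC1CN1C(=O)Nc1cccc2ccccc12` carry aryl groups there. In a functional assay on OVCAR-3 cells (Homo sapiens) for inhibition (on this read-out lower numbers stand for stronger inhibition and higher numbers for weaker inhibition), compound 1 gives 12000 nM, compound 2 gives 6500 nM and compound 3 gives 5900 nM. Compound 1 thus stands with the highest number of the three; its gap to compound 2 lies within the usual scatter of repeated measurements, while its gap to compound 3 lies just beyond it. Among the measured compounds shown here, no pair of measured compounds differs in a single place, so no measured step is available to calibrate the change below.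

Compound 4 `N#CC1CN1C(N)=O` is the unsubstituted urea. From compound 1 to compound 4 the change is hydrogen in place of butyl on an amide-type nitrogen. Every measured compound carries some group on that nitrogen, so the measured set gives no direct reading of what its complete removal does. The expectation is nevertheless a step toward higher numbers, that is weaker inhibition, somewhat beyond the scatter: the expected step is a 2.5-fold higher number from compound 1 to compound 4 (0.40 log units; beyond the scatter). Compound 4 is estimated at 30000 nM, with a range from 10000 nM to 90000 nM.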

Compound 4, half-maximal inhibitory concentration: > 90000 nM
Compound 4: a limit, no number; the forecaster's own chance of this, stated with the estimate: 35%; middle value at least 3.0-fold (0.47 log units) away from the limit.
By their numbers in this assay, from the lowest: compounds 3, 2 and 1 (each within the scatter of the next, the first and the last beyond it). At a limit, above all of these: compound 4.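

In this assay compound 4 gives > 90000 nM, which is a limit of the assay and not a number. Hydrogen in place of butyl on this amide-type nitrogen gives the first step that can be read in the series, an at least 7.5-fold higher number from compound 1 to compound 4 (0.87 log units; beyond the scatter), and so shows what compounds carrying a group there could not: complete removal of the group moves the read-out beyond the scatter, toward weaker inhibition. This reading fixes only the minimum size of the step, and its full size stays unknown, as the only reading for the unsubstituted urea is the limit: the limit of > 90000 nM in this assay, at which 1 of the 4 values shown sits.

The compounds shown leave open how much of the butyl chain is needed, as a methyl or ethyl group on that nitrogen could show whether a short chain keeps a measurable number, while a longer chain such as octyl could show whether the number falls further. They also leave open whether an amine or a carboxylic acid carried on such a chain would be tolerated in this read-out.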